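Moving a fluorine from compound 3 to compound 4

The compounds below may be only part of what the source reports. "The series", "measured", "known", "first", "only" and "open" are said of these compounds alone.

Values measured in an ADME assay on HEK293 cells (Homo sapiens) for cytotoxicity, with a stated time of 72 h; on this read-out higher numbers stand for an effect only at larger amounts of compound and lower numbers for an effect already at smaller amounts:
compound 1 `C=C[C@@](C)(/C=C/c1ccc(OCc2ccccc2)cc1)CCC=C(C)C`: > 36600 nM
compound 2 `C=C[C@@](C)(/C=C/c1ccc(Nc2ccc(OC)cc2)cc1)CCC=C(C)C`: > 36600 nM
compound 3 `C=C[C@@](C)(/C=C/c1ccc(-c2ccc(F)cc2)cc1)CCC=C(C)C`: > 36600 nM

None of these three readings is a number, and the series offers only (the limit of > 36600 nM in this assay, at which 3 of the 3 values shown sit). Compound 3 gives > 36600 nM, which is a limit and not a number. Its position relative to compound 1 and compound 2 therefore cannot be ranked.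

Compound 4 `C=C[C@@](C)(/C=C/c1ccc(-c2cccc(F)c2)cc1)CCC=C(C)C` keeps the shared core and differs in one group: 3-fluorophenyl in place of 4-fluorophenyl on an aromatic carbon. The exchange takes place on an aromatic carbon of a six-membered aromatic ring of carbon only, para to a large group, and the fluorine-bearing group leaves and enters with the same counted make-up.

Two measured steps end at compound 3 and bear on this change: a step that the two limits leave unreadable from compound 1 to compound 3 and a step that the two limits leave unreadable from compound 2 to compound 3. Neither gives a size to carry over, so the series offers no sign of a shift in this assay. The expected change is a number no higher from compound 3 to compound 4 (the limit leaves the size open), with no step beyond the scatter and no direction foreseen. For compound 4 the estimated value is 36600 nM, with an expected range from 18000 nM to 73000 nM.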

Compound 4, half-maximal effective concentration: > 36600 nM
Compound 4 gave a limit, no number; the forecaster's own chance of this, stated with the estimate: 85%; the middle value sits exactly at the limit.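

In this assay compound 4 gives > 36600 nM, which is a limit and not a number. No step can be read between compound 4 and compound 1, compound 2 or compound 3, and all four readings rest on the same limit: the limit of > 36600 nM in this assay, at which 4 of the 4 values shown sit.

The compounds shown leave open whether moving the fluorine changes the read-out in this assay at all, and at what amount of compound any of the four would show an effect.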